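Swapping a nitrile for a methoxy on the aryl ring

The source may report more compounds than this note shows. Statements on the series, on what has been measured and on what is new or still open speak of the compounds shown alone.

Measured so far:
- compound 1 `COc1cccc2cc(C(=O)Nc3c(C#N)ncn3-c3ccc(C#N)cc3)c(=N)oc12`: 18%
- compound 2 `COc1cccc2c1OC(C)(O)C(C(C)=O)=C2`: 6%
- compound 3 `N=c1oc2ccc(Br)cc2cc1C(=O)NCC(O)CO`: 11%

These three compounds were tested in an assay on CHO cells for displacement of a labelled ligand from adenosine receptor A1 (Homo sapiens), read by scintillation counting, with a stated time of 60 min, tested at 10 uM; on this read-out higher numbers stand for more inhibition at the one concentration tested (going by the name of the read-out) and lower numbers for less inhibition. Compound 1 gives the highest of the three numbers, 18%. Its nearest neighbour is compound 3, whose value lies within the usual scatter of compound 1, so the two cannot be told apart. Compound 2 sits beyond the scatter, lower than compound 1. All three numbers are modest in this assay.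

The unmeasured compound 4 `COc1ccc(-n2cnc(C#N)c2NC(=O)c2cc3cccc(OC)c3oc2=N)cc1` shares the core of compound 1 and differs in a single place: methoxy in place of cyano on an aromatic carbon. Within the data shown here, no measured pair shows this particular change, so its effect is unknown. Given that every number so far is low, and that the change keeps the same count of heavy atoms and acceptors, the step of a number 3 percentage points lower from compound 1 to compound 4 (within the scatter) is expected to be small, with no direction beyond the scatter. Compound 4 is estimated at 15%, within a range from 0% to 35%.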

Compound 4, a percentage reported as inhibition, at one concentration (the size of the read-out at that concentration, not a potency): 37%
Beside the measured number, compound 4's estimate is 22 percentage points below it; measured number outside the range, above it.
By their numbers in this assay, from the lowest: compounds 2, 3 and 1 (each within the scatter of the next, the first and the last beyond it); then compound 4.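

In this assay, among these compounds, going from 4-cyanophenyl to 4-methoxyphenyl gives a number 19 percentage points higher from compound 1 to compound 4 (beyond the scatter), the first step that can be read for a change in one place. It shows that the number responds to what sits on this aromatic carbon, para to a large group. The two groups match in heavy atoms and hydrogen-bond acceptors, so those counts do not separate them, and no measurement at hand accounts for the step.

A single step cannot show whether methoxy is special here, or whether an amine, a hydroxyl or a longer chain such as ethoxy at the same place would give a higher or lower number. From the compounds shown here alone, whether the same swap would give a similar step on a different core also stays open.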